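A few compounds are considered here, and "the series" means these few. Any claim that something is new, unique, unknown or untested is made for them only; others in the source may bear on it.

Measured so far in a functional assay on SF-268 cells (Homo sapiens) for cytotoxicity, read by sulforhodamine B assay, with a stated time of 48 h; a higher number here means a weaker inhibitor of growth, a lower number a stronger inhibitor of growth:
compound 1 `ClCc1ccc(Cn2cnc3c(Cl)ncnc32)cc1` gives 640 nM;
compound 2 `ClCc1ccccc1Cn1cnc2c(Cl)ncnc21` gives 3230 nM;
compound 3 `ClCc1ccc(Cn2cnc3nc(Cl)nc(Cl)c32)cc1` gives 1990 nM.

Among these three numbers compound 3 stands second highest. Its nearest neighbour is compound 2, whose number is higher but within the scatter of repeated runs; compound 1 lies furthest away, with a lower number beyond the scatter.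

Compound 4 `ClCc1ccc(Cn2cnc3ncnc(Cl)c32)cc1` has not yet been tested. Compared with compound 3, the change is hydrogen in place of chloro on an aromatic carbon. For the measured compounds named here, no pair of measured compounds differs by exactly this change, so nothing on hand shows its effect. Compound 4 is expected to stay close to compound 3, with a step of a 1.3-fold lower number from compound 3 to compound 4 (0.12 log units; within the scatter) not clearly beyond the scatter in either direction, giving an estimated 1500 nM and a likely range from 500 nM to 5000 nM.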

Compound 4, concentration for 50% growth inhibition: 1650 nM
Compound 4: the middle estimate sits 1.1-fold (0.04 log units) below what was measured; measured number inside the range.
By their numbers in this assay, from the lowest: compound 1; then compounds 4, 3 and 2 (each within the scatter of the next).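

In this assay the step of a 1.2-fold lower number from compound 3 to compound 4 (0.08 log units; within the scatter) stays within the scatter, so swapping chloro for hydrogen on the aromatic carbon between two ring nitrogen atoms has no effect that can be told apart from repeat-to-repeat variation. For the compounds shown here, this is the first direct reading of this position, as no earlier pair differed in one place only. Nothing measured here explains this result.

Going by these compounds, it remains open whether a larger group on this carbon, such as an amine or a methoxy group, would shift the number. On these data alone, the effect of replacing the remaining chloro group with hydrogen also remains open.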